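The source may hold more compounds than are shown below. What is called first, only, known or untested is meant among the compounds shown, and "the series" means these compounds.

Measured compounds:
compound 1 `CCCCCCCCCCCCC/C=C/[C@H](O)[C@H](COP(=O)(O)O)N=[N+]=[N-]` — 28800 nM
compound 2 `CCCCCCCCCCCCCCC[C@H](O)[C@H](COP(=O)(O)O)N=[N+]=[N-]` — 21800 nM
compound 3 `CCCCCCCCCCCCCCC[C@H](O)[C@@H](COP(=O)(O)O)N=[N+]=[N-]` — 10800 nM

In an assay on isolated protein for inhibition of sphingosine-1-phosphate lyase 1 (Homo sapiens), read by fluorescence, with a stated time of 1 h (on this read-out higher numbers stand for weaker inhibition and lower numbers for stronger inhibition), compound 1 gives the highest of the three numbers. Compound 2 stands nearest to it, the two values lying within the scatter of each other, while compound 3 stands furthest, with a number beyond the scatter lower than that of compound 1.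

Compound 4 `CCCCCCCCCCCCC/C=C/[C@@H](O)[C@@H](COP(=O)(O)O)N=[N+]=[N-]` is the next compound under consideration. It keeps every atom and bond of compound 1; the change is the two compounds have the same atoms and bonds; at least one stereo element is drawn with a configuration in one of them and without one in the other: 2 of 4 stereo elements differ; a stereocentre at a saturated chain carbon is drawn S in compound 1 and R in compound 4; a stereocentre at a saturated chain carbon is drawn S in compound 1 and R in compound 4. Among the compounds with values here, the only measured step that touches this kind of change is the one from compound 2 to compound 3, where a single stereocentre at a saturated chain carbon is drawn the other way and the number moves by a 2.0-fold lower number from compound 2 to compound 3 (0.31 log units; beyond the scatter); that step rests on (the fact that one of compounds 2 and 3 is drawn with a defined configuration and the other without, at the place where they differ). Within the data shown here, compound 4 differs from compound 1 at two such centres, so that step covers only part of the change, and the stereo element carrying the hydroxyl has no measured counterpart. A modest step towards a lower number is the most that can be expected in this assay, with considerable room for no change at all. Compound 4 is therefore estimated at 18000 nM, in the range 7000 nM to 45000 nM, corresponding to an expected step of a 1.6-fold lower number from compound 1 to compound 4 (0.20 log units; within the scatter).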

Compound 4, half-maximal inhibitory concentration: 22900 nM
Compound 4: the middle estimate sits 1.3-fold (0.10 log units) below what was measured, within the range that was stated.
By their numbers in this assay, from the lowest: compound 3; then compounds 2, 4 and 1 (each within the scatter of the next).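

In this assay, drawing two stereocentres at saturated chain carbons the other way gives a 1.3-fold lower number from compound 1 to compound 4 (0.10 log units; within the scatter), so this double change in the chain with the double bond produces no readable shift. The single-centre step in the saturated chain, a 2.0-fold lower number from compound 2 to compound 3 (0.31 log units; beyond the scatter), therefore finds no readable counterpart in the pair with the double bond. This reading carries a caveat about how the structures are drawn: the fact that one of compounds 1 and 4 is drawn with a defined configuration and the other without, at the place where they differ

The separate contribution of each of the two centres in the chain with the double bond stays open, as the pair shown changes both together. Also open, going by these compounds, is how the number would respond to an amine in place of the azide or a carboxylic acid in place of the phosphate.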